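Replacing the fluorophenyl on the sulfonyl of compound 3

This account rests on a few compounds, and the source may have more. Where it says the series, first, only, none or still open, it means among the compounds named here.

The three measured compounds share a core carrying a sulfonyl group on a piperidinyl-substituted bicyclic aromatic system. Compound 1 `CC(C)N1CCCC(n2cc(S(=O)(=O)C3=C(Cl)NC4SC=CN34)c3cccnc32)C1` bears an isopropyl on the piperidine nitrogen and, in an assay on HeLa cells for displacement of a labelled ligand from 5-hydroxytryptamine receptor 6 (Homo sapiens) (a lower number here means a stronger inhibitor, a higher number a weaker inhibitor), compound 1 gives 1.7 nM. Compound 2 `CN1CCCC(n2cc(S(=O)(=O)c3ccc(Cl)cc3)c3cccnc32)C1` gives 11.5 nM, and compound 3 `CN1CCCC(n2cc(S(=O)(=O)c3cccc(F)c3)c3cccnc32)C1` gives 4.7 nM. Compound 3 thus stands second highest of the three numbers, between compound 2 and compound 1.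

Among the compounds with values here, the one measured step, a 2.4-fold lower number from compound 2 to compound 3 (0.39 log units; beyond the scatter), concerns the sulfonyl substituent and is modest. Compound 4 `CN1CCCC(n2cc(S(=O)(=O)C3=C(Cl)NC4SC=CN34)c3cccnc32)C1` also changes that substituent: a group of 9 heavy atoms (5 carbon, 2 nitrogen, 1 sulfur, 1 chlorine; 2 five-membered non-aromatic rings with 2 hetero atoms each) in place of a group of 7 heavy atoms (6 carbon, 1 fluorine; one six-membered aromatic ring of carbon only), on a sulfonyl sulfur. Within the data shown here, no measured step covers this exact change with the methyl on the piperidine nitrogen; compound 1 carries the same entering group with an isopropyl there and shows the lowest number of the set. On that basis a lowering step of moderate size is expected, a 1.9-fold lower number from compound 3 to compound 4 (0.27 log units; within the scatter). Compound 4 is therefore estimated at 2.5 nM, with a range from 1 nM to 6 nM.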

Compound 4, inhibition constant: 2 nM
Estimate against measurement, compound 4: 1.3-fold (0.10 log units) above; the range from low to high includes it.
By their numbers in this assay, from the lowest: compounds 1 and 4 (each within the scatter of the next); then compound 3; then compound 2.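

With methyl kept on the amine nitrogen in a ring, the group of 9 heavy atoms on the sulfonyl sulfur gives lower numbers in this assay than either carbon-only aromatic ring, with a 2.4-fold lower number from compound 3 to compound 4 (0.37 log units; beyond the scatter) and a 5.8-fold lower number from compound 2 to compound 4 (0.76 log units; beyond the scatter). Exchanging the substituent on that nitrogen, with this sulfonyl group in place, gives a 1.2-fold higher number from compound 1 to compound 4 (0.07 log units; within the scatter), so the low number of compound 1 does not depend on its isopropyl. No independent measurement bears on why this sulfonyl group gives the lower numbers.

The compounds shown leave open whether methyl and isopropyl also match when the sulfonyl sulfur carries 3-fluorophenyl. On these data alone, how a longer chain on the amine nitrogen, or a carboxylic acid on the sulfonyl group, would read also remains open.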